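A few compounds are considered here, and "the series" means these few. Any claim that something is new, unique, unknown or untested is made for them only; others in the source may bear on it.

Three members of one series have been measured in a functional assay on SN12C cells (Homo sapiens) for inhibition, read by sulforhodamine B assay, with a stated time of 48 h; on this read-out lower numbers stand for stronger inhibition of growth and higher numbers for weaker inhibition of growth. Compound 1 `COc1cc(C)cc(-c2nn(CC#N)cc2-c2ccc(-c3cccc(C(C)=O)c3)nc2)c1` gives 6080 nM in this assay, compound 2 `Cc1cc(O)cc(-c2nn(CC#N)cc2-c2ccnc(-c3ccc(Oc4ccccc4)cc3)c2)c1` gives 1800 nM, and compound 3 `COc1cc(C)cc(-c2nn(CC#N)cc2-c2ccnc(-c3ccc(N(C)C)cc3)c2)c1` gives 730 nM. Compound 3 thus stands lowest of the three numbers: its nearest neighbour is compound 2, whose number is higher by an amount beyond the usual scatter, and compound 1 lies furthest away, also beyond the scatter.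

Compound 4 `Cc1cc(O)cc(-c2nn(CC#N)cc2-c2ccnc(-c3ccc(N(C)C)cc3)c2)c1` has not yet been measured. It differs from compound 3 in one place: hydrogen in place of methyl on an oxygen on an aromatic ring, so that 3-methoxy-5-methylphenyl becomes 3-hydroxy-5-methylphenyl. For the measured compounds named here, no pair among the measured compounds shows this change on its own; compound 2 carries the hydroxy form, but it differs from compound 3 in another part of the molecule as well, so the two cannot be read as a single step.

Going by the values given here, with no direct precedent in the data, a step from compound 3 to compound 4 of a 1.2-fold higher number from compound 3 to compound 4 (0.09 log units; within the scatter) is expected, which is to say no shift beyond the scatter in either direction. Compound 4 is therefore estimated at 900 nM, within a range of 300 nM to 2700 nM.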

Compound 4, concentration for 50% growth inhibition: 4280 nM
For compound 4 the middle estimate is 4.8-fold (0.68 log units) below the measured one; measured number outside the range, above it.
By their numbers in this assay, from the lowest: compound 3; then compound 2; then compounds 4 and 1 (each within the scatter of the next).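

In this assay, for the compounds shown here, the methyl on the oxygen of the 3-methoxy-5-methylphenyl group proves to count: with the dimethylamino group held constant, hydrogen in its place gives a 5.9-fold higher number from compound 3 to compound 4 (0.77 log units; beyond the scatter) and so moves towards weaker inhibition of growth, the first single-change reading at this position. With the hydroxy form held constant, dimethylamino in place of phenoxy gives a 2.4-fold higher number from compound 2 to compound 4 (0.38 log units; beyond the scatter), so in the 3-hydroxy-5-methylphenyl setting the phenoxy compound has the lower number and the dimethylamino group does not by itself secure the lowest number of the series. Nothing available explains either step.

Going by these compounds, how an ethoxy group, a longer alkoxy chain or an amine would read in place of the methoxy stays open, so it cannot yet be said whether the methoxy is specifically favoured or whether the hydroxy is simply disfavoured. On these data alone, it also stays open how phenoxy would read alongside the methoxy form, which would show whether the effect of the methyl on the oxygen depends on the group at the other end of the molecule.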